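Cytotoxicity series: ethylamino replacing hydroxyethylpiperazine

The compounds below may be only part of what the source reports. "The series", "measured", "known", "first", "only" and "open" are said of these compounds alone.

Compound 1 `Cc1ccc2c(NCc3ccc(NC(=O)C4CCN(C(=O)OC(C)(C)C)CC4)cc3)nc(N(C)C)nc2c1` reaches only a limit in a functional assay on SV5A8 cells (Homo sapiens) for cytotoxicity (a lower number here means a stronger inhibitor, a higher number a weaker inhibitor), namely > 4820 nM. Compound 3 `Cc1ccc2c(NCc3ccc(NC(=O)C4CCN(Cc5ccc(F)cc5Cl)CC4)cc3)nc(N(C)C)nc2c1` likewise gives only a limit, > 5910 nM. The step that the two limits leave unreadable from compound 1 to compound 3 therefore cannot be sized. Compound 2 `Cc1ccc2c(NCc3ccc(NC(=O)C4CCN(Cc5ccccc5)CC4)cc3)nc(N3CCNC(CCO)C3)nc2c1` stands no differently: in this assay compound 2 returns only a limit, > 8420 nM. All three values shown are limits (the limit of > 4820 nM in this assay, at which 1 of the 3 values shown sits, (the limit of > 5910 nM in this assay, at which 1 of the 3 values shown sits), (the limit of > 8420 nM in this assay, at which 1 of the 3 values shown sits)). Compound 4 `CCNc1nc(NCc2ccc(NC(=O)C3CCN(Cc4ccccc4)CC3)cc2)c2ccc(C)cc2n1` differs from compound 2 by ethylamino in place of 3-(2-hydroxyethyl)piperazin-1-yl on an aromatic carbon. Within the data shown here, no measured step bears on this change; the one step present, from compound 1 to compound 3, is unreadable. With every neighbour at a limit, compound 4 is expected to sit at a limit as well, and the step that the limit leaves unreadable from compound 2 to compound 4 is expected to be none beyond the scatter. The estimate for compound 4 in this assay is 10000 nM, within 3000 nM to 40000 nM.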

Compound 4, half-maximal inhibitory concentration: > 2140 nM
Compound 4: no number, only a limit (the forecaster's own chance of this, stated with the estimate: 80%); the middle value lies beyond the limit too.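

Compound 2 and compound 4 both return only limits, and the step between them cannot be read. The compounds shown leave open how ethylamino compares with 3-(2-hydroxyethyl)piperazin-1-yl, and where any of the four would fall as an actual number in this assay.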